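Basic amine in place of methoxy on the triazole chain

The source may report more compounds than this note shows. Statements on the series, on what has been measured and on what is new or still open speak of the compounds shown alone.

Among the measured compounds shown here, compound 1 `COCCc1cn(-c2ccc(NC(=O)Nc3ccccc3C)cc2)nn1` is the only member of the series with a numerical result: in an assay on isolated protein for inhibition of ATP-dependent RNA helicase DDX3X (Homo sapiens), read by FRET, with stated times of 30 s and 40 min (a lower number here means a stronger inhibitor, a higher number a weaker inhibitor), compound 1 gives 1000 nM. Compound 2 `O=C(Nc1ccc(-n2cc(CCO[C@H]3O[C@@H](CO)[C@H](O)[C@@H]3O)nn2)cc1)Nc1ccccc1C(F)(F)F` is reported in this assay as "not active" (no number reported), without a number. Compound 3 `O=C(O)CCc1cn(-c2ccc(NC(=O)Nc3ccccc3C(F)(F)F)cc2)nn1` stands in this assay as "not determined" (no result reported). For the measured compounds named here, no pair of measured compounds differs in a single place, so no measured step exists to anchor an expectation. Compound 4 `Cc1ccccc1NC(=O)Nc1ccc(-n2cc(CCCN3CCN(C)CC3)nn2)cc1` differs from compound 1 by (4-methylpiperazin-1-yl)methyl in place of methoxy on a saturated chain carbon, two bonds along the chain from an aromatic carbon. With nothing comparable measured, the step from compound 1 to compound 4 is expected to be small, a 1.3-fold lower number from compound 1 to compound 4 (0.10 log units; within the scatter), in either direction and not clearly beyond the scatter. Compound 4 is estimated at 800 nM in this assay, within 200 nM to 4000 nM.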

Compound 4, half-maximal inhibitory concentration: 40100 nM
Estimate against measurement, compound 4: 50-fold (1.70 log units) below, and the stated range ends below it.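

In this assay, this position does not accept every replacement of methoxy: putting (4-methylpiperazin-1-yl)methyl on the saturated chain carbon gives a 40-fold higher number from compound 1 to compound 4 (1.60 log units; beyond the scatter). This first measured step shows that a change at the end of this chain alone can move the number well beyond the scatter. Nothing measured here bears on the cause of this loss.

From the compounds shown here alone, it remains open whether a dimethylamino group, a morpholine ring or a hydroxyl at the same chain end would keep the number of compound 1. Going by these compounds, the effect of a shorter chain carrying the same methylpiperazine ring also remains open.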